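Fluoro to propylcarbamoyl on the fused ring of compound 2

This account rests on a few compounds, and the source may have more. Where it says the series, first, only, none or still open, it means among the compounds named here.

Measured so far in a functional assay on K562 cells (Homo sapiens) for antiproliferative activity, read by CCK-8 assay, with a stated time of 72 h; a lower number here means a stronger inhibitor of growth, a higher number a weaker inhibitor of growth:
compound 1 `CCCNS(=O)(=O)c1ccc(Nc2ncc3c(n2)N(C2CCCC2)[C@H](CC)C(=O)N3C)cc1` gives 548 nM
compound 2 `CC[C@@H]1C(=O)N(C)c2cnc(-n3ccc4cc(F)ccc43)nc2N1C1CCCC1` gives 21200 nM
compound 3 `CCCNS(=O)(=O)c1ccc(Nc2ncc3c(n2)N(c2ccn(C)n2)C(CC)C(=O)N3C)cc1` gives 2260 nM

Of the three numbers, compound 2 stands highest in this assay. Its nearest neighbour is compound 3, and the gap between the two lies beyond the scatter; compound 1 is furthest away, also beyond the scatter. Compound 1 and compound 3 share the propylsulfonamide-bearing aniline, whereas compound 2 carries a fluoro-substituted fused ring in that position of the shared core.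

Compound 4 `CCCNC(=O)c1ccc2c(ccn2-c2ncc3c(n2)N(C2CCCC2)[C@H](CC)C(=O)N3C)c1` is not yet measured. It differs from compound 2 in one place: propylcarbamoyl in place of fluoro on an aromatic carbon. The propylcarbamoyl group thus puts a hydrogen-bond donor and a hydrogen-bond acceptor on the fused ring, while compound 4 keeps the cyclopentyl and ethyl groups of compound 1 on the core.

For the measured compounds named here, no step between two measured compounds is available, so the expectation rests on comparison alone. Because compound 1 gives 548 nM with a propyl-bearing side group and compound 2 gives 21200 nM without one, the number for compound 4 is expected to move downward, by a step of an 8.5-fold lower number from compound 2 to compound 4 (0.93 log units; beyond the scatter), clearly beyond the scatter. Compound 4 is therefore estimated at 2500 nM, with a range from 600 nM to 10000 nM.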

Compound 4, concentration for 50% growth inhibition: 395 nM
The estimate for compound 4 lay 6.3-fold (0.80 log units) above the measured number; measured number outside the range, below it.
By their numbers in this assay, from the lowest: compounds 4 and 1 (each within the scatter of the next); then compound 3; then compound 2.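

In this assay, for the compounds shown here, propylcarbamoyl in place of fluoro on this aromatic carbon gives a 54-fold lower number from compound 2 to compound 4 (1.73 log units; beyond the scatter), the first step in which only one place changes. The earlier compounds shown here differed in more than one place and could not isolate this position. Here the cyclopentyl and ethyl groups and the rest of the shared core stay fixed, and only the group on this carbon differs. No measurement shown explains the size of this step, which stands as an observed difference in antiproliferative activity only.

The change brings in the carbonyl, the amide hydrogen and the propyl chain together, and the compounds shown do not separate their contributions. As far as these compounds go, it remains open whether a methylcarbamoyl or dimethylcarbamoyl group, a longer chain on the amide nitrogen, or a carboxylic acid on the same aromatic carbon would keep the number near that of compound 4 at 395 nM.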